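The source may report more compounds than this note shows. Statements on the series, on what has been measured and on what is new or still open speak of the compounds shown alone.

Compound 1 `O=C(Nc1cccc(-n2cc(-c3ccncc3)c(-c3cc(O)cc(Cl)c3)n2)c1)Nc1ccc(Cl)c(Cl)c1` carries a urea bearing a dichlorophenyl group and, on its shared core, a 3-chloro-5-hydroxyphenyl group. In a functional assay on K562 cells (Homo sapiens) for inhibition, read by sulforhodamine B assay, with a stated time of 48 h, tested at 1 uM (a lower number here means a stronger effect, a higher number a weaker effect of the compound at the concentration tested), compound 1 gives 83%, the higher of the two numbers recorded so far and therefore the weaker effect at the concentration tested. Going by the values given here, the only other number comes from compound 2 `COc1cc(Cl)cc(-c2nn(-c3cccc(NC(=O)Nc4cc(C(F)(F)F)cc(C(F)(F)F)c4)c3)cc2-c2ccncc2)c1`, which in this assay gives 18%, a number far lower than that of compound 1 and beyond the scatter. Among the compounds with values here, compound 2 differs from compound 1 in more than one place, so no single step between them is measured; their two values show only that compound 2 produces the much stronger effect.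

Compound 3 `COc1cc(Cl)cc(-c2nn(-c3cccc(NC(=O)Nc4ccc(Cl)c(Cl)c4)c3)cc2-c2ccncc2)c1` is not yet measured. It differs from compound 1 by methyl in place of hydrogen on an oxygen on an aromatic ring, turning the hydroxy into a methoxy so that the 3-chloro-5-hydroxyphenyl becomes the 3-chloro-5-methoxyphenyl that compound 2 also carries, while the dichlorophenyl urea of compound 1 is kept. Because compound 2 gives 18% with that methoxy in place, a drop beyond the scatter is expected; the estimated step is a number 28 percentage points lower from compound 1 to compound 3 (beyond the scatter). For compound 3 the expected value in this assay is therefore 55%, within a range from 25% to 88%.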

Compound 3, a percentage reported as activity, at one concentration (the size of the read-out at that concentration, not a potency): 67%
For compound 3 the middle estimate is 12 percentage points below the measured one, and the stated range covers the measured number.
By their numbers in this assay, from the lowest: compound 2; then compound 3; then compound 1.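

Replacing the hydrogen on the oxygen with methyl, the first single change measured in this series, gives a number 16 percentage points lower from compound 1 to compound 3 (beyond the scatter) in this assay, so a change this small at this position is enough to lower the number, though only modestly. Compound 3 (67%) still stands well above compound 2 (18%), although both carry the 3-chloro-5-methoxyphenyl group, so the methoxy alone does not bring the number close to that of compound 2, and the two compounds differ only in the aryl group on the urea. Nothing measured here accounts for the step from hydroxy to methoxy at this position.

The compounds shown leave open whether a larger group on this oxygen, such as an ethoxy or a longer chain, or an amine in place of the hydroxy, would take the number lower or raise it again. They also leave open whether the change from hydroxy to methoxy would give a step of similar size with the urea of compound 2 in place of the dichlorophenyl urea.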